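The source may hold more compounds than are shown below. What is called first, only, known or untested is meant among the compounds shown, and "the series" means these compounds.

Measured compounds:
compound 1 `CC(C)(NC(=O)c1cccc2c(Br)c(-c3ccc(Cl)cc3)oc12)C(=O)O`: 1760 nM
compound 2 `O=C(NC1(C(=O)O)CCCCC1)c1cccc2cc(-c3ccc(Cl)cc3)oc12`: 120 nM
compound 3 `O=C(NC1(C(=O)O)CCCC1)c1cc(F)cc2cc(-c3ccc(Cl)cc3)oc12`: 99 nM

Compound 3 gives the lowest of the three numbers in an assay on isolated protein for inhibition of endoplasmic reticulum aminopeptidase 1 (Homo sapiens), with stated times of 15 min and 20 min; a lower number here means a stronger inhibitor, a higher number a weaker inhibitor. Its nearest neighbour is compound 2, whose number in this assay lies higher by a margin within the usual scatter, so the two cannot be put in order. Among the measured compounds shown here, compound 1 stands far above both, beyond the scatter; no single-point step connects it to compound 3, so that gap is noted without being assigned to any one change.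

The next compound, compound 4 `O=C(NC1(C(=O)O)CC1)c1cc(F)cc2cc(-c3ccc(Cl)cc3)oc12`, differs from compound 3 in one place: 1-carboxycyclopropyl in place of 1-carboxycyclopentyl on an amide-type nitrogen. For the measured compounds named here, no measured pair shows this change, so the present numbers fix neither its size nor its direction. The only related observation is that compound 2 and compound 3, which carry different ring sizes at this position among other differences, sit within the scatter of each other. On that thin basis a modest weakening is expected for compound 4, with the step of a 2.5-fold higher number from compound 3 to compound 4 (0.40 log units; beyond the scatter) likely small and possibly not beyond the scatter. Compound 4 is therefore estimated at 250 nM, with a range from 80 nM to 800 nM.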

Compound 4, half-maximal inhibitory concentration: 1120 nM
Compound 4: the middle estimate sits 4.5-fold (0.65 log units) below what was measured; measured number outside the range, above it.
By their numbers in this assay, from the lowest: compounds 3 and 2 (each within the scatter of the next); then compounds 4 and 1 (each within the scatter of the next).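

Working notes on the ring on the amide-type nitrogen: in this assay this is the first position in the series where a single change can be read, and going from 1-carboxycyclopentyl to 1-carboxycyclopropyl gives an 11-fold higher number from compound 3 to compound 4 (1.05 log units; beyond the scatter) with the rest of the molecule held fixed. The position is therefore sensitive to the identity of this ring, and the five-membered ring supports much stronger inhibition than the three-membered ring on this fluorine-bearing core. Among the compounds shown here, no earlier pair could establish this point. None differed in this place alone. The data on hand offer no measurement that accounts for this step.

Going by these compounds, two points stay open: whether inhibition changes gradually or abruptly with ring size, which 1-carboxycyclobutyl on the same core would help to settle, and whether a step of this size also holds on a core without the fluorine. The compounds shown also leave open how much the carboxylic acid itself contributes at this position, since it is present in every compound here, and a primary amide or a methyl ester in its place would test that directly.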